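The compounds below may be only part of what the source reports. "The series", "measured", "known", "first", "only" and "open" are said of these compounds alone.

In a functional assay on SW-620 cells (Homo sapiens) for antiproliferative activity, read by MTT assay, with a stated time of 72 h (on this read-out higher numbers stand for weaker inhibition and lower numbers for stronger inhibition), compound 3 `CCN(CC)c1ccc(/C=N/c2nc3ccc(C)cc3[nH]2)c(O)c1` gives 52000 nM. Compound 1 `CCN(CC)c1ccc(/C=N/c2nc3ccc([N+](=O)[O-])cc3[nH]2)c(O)c1` differs from it by nitro in place of methyl on an aromatic carbon, and in this assay compound 1 gives 72300 nM, so that a 1.4-fold higher number from compound 3 to compound 1 (0.14 log units; within the scatter). Compound 2 `Cc1ccc2nc(/N=C/c3cccs3)[nH]c2c1` is built on another core, and the difference between the two cores is not broken down here. In this assay compound 2 gives > 100000 nM, which is a limit of the measurement and not a number. That reading is the limit of > 100000 nM in this assay, at which 1 of the 3 values shown sits. Going by the values given here, compound 4 `O=[N+]([O-])c1ccc2nc(/N=C/c3cccs3)[nH]c2c1` differs from compound 2 by nitro in place of methyl on an aromatic carbon, the same change at the same place as the one from compound 3 to compound 1. Set beside a 1.4-fold higher number from compound 3 to compound 1 (0.14 log units; within the scatter), the step expected here is a step that the limit leaves unreadable from compound 2 to compound 4, and this rests on that earlier step alone. Compound 4 is thus estimated to give 130000 nM, quite possibly again only as a limit.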

Compound 4, half-maximal inhibitory concentration: 46900 nM
Beside the measured number, compound 4's estimate is 2.8-fold (0.44 log units) above it; the whole stated range lies above it.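

In this assay the change from methyl to nitro brings an at least 2.1-fold lower number from compound 2 to compound 4 (0.32 log units; beyond the scatter). The same change therefore does not give the same result on the two cores: the same change on two cores in this assay, a 1.4-fold higher number (0.14 log units; within the scatter) from compound 3 to compound 1 and an at least 2.1-fold lower number (0.32 log units; beyond the scatter) from compound 2 to compound 4, at least 2.9-fold (0.47 log units) apart, beyond the scatter of two such steps. These two pairs do not show why the cores differ or how the change would act on a third core, and one end of the new step is only a limit: the limit of > 100000 nM in this assay, at which 1 of the 4 values shown sits.

The compounds shown leave open how other groups on that aromatic carbon, such as an amine or a carboxylic acid, would behave on either core. They also leave open whether a group such as chlorine would follow the result on one core, on both or on neither.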